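Adding one methyl group to compound 2

The source may hold more compounds than are shown below. What is called first, only, known or untested is meant among the compounds shown, and "the series" means these compounds.

Values in a functional assay on HT-29 cells (Homo sapiens) for cytotoxicity, read by MTT assay, with a stated time of 72 h; a higher number here means a weaker inhibitor, a lower number a stronger inhibitor
compound 1 `Cc1ccc(F)cc1NC(=O)CN1CCN(c2nnc(Cc3ccccc3)c3ccccc23)CC1` gives 171000 nM
compound 2 `O=C(CN1CCN(c2nnc(Cc3ccncc3)c3ccccc23)CC1)Nc1cccc(F)c1` gives 6130 nM

Compound 2 has the lower of the two numbers, which makes it the stronger inhibitor here, and its gap to compound 1 lies beyond the usual scatter. These two compounds differ in more than one place, so no single change can be held responsible for that gap.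

Compound 3 `Cc1ccc(F)cc1NC(=O)CN1CCN(c2nnc(Cc3ccncc3)c3ccccc23)CC1` is compound 2 with one edit: methyl in place of hydrogen on an aromatic carbon turns the 3-fluorophenyl into 5-fluoro-2-methylphenyl, with methyl in place of hydrogen on an aromatic carbon, ortho to a large group and para to a fluoro group. For the measured compounds named here, the same group occurs in compound 1 at 171000 nM in this assay but no measured pair isolates the methyl, so this is only a weak hint. A small move toward a higher number is expected, possibly none beyond the scatter. The estimate amounts to a 1.5-fold higher number from compound 2 to compound 3 (0.17 log units; within the scatter) as the expected change in this assay for this one methyl. For compound 3 the estimated value is 9000 nM with an expected range from 2500 nM to 35000 nM in this assay on this reasoning.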

Compound 3, half-maximal inhibitory concentration: 470 nM
The estimate for compound 3 lay 19-fold (1.28 log units) above the measured number; measured number below the stated range.
By their numbers in this assay, from the lowest: compound 3; then compound 2; then compound 1.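

In this assay a single methyl in place of hydrogen on an aromatic carbon, which turns 3-fluorophenyl into 5-fluoro-2-methylphenyl, gives a 13-fold lower number from compound 2 to compound 3 (1.12 log units; beyond the scatter) and so shows that this spot on the ring can shift the result strongly with just one added carbon. Compound 3 also lets a single change be read on the other side of the molecule, where pyridin-4-yl in place of phenyl on the saturated chain carbon gives a 360-fold lower number from compound 1 to compound 3 (2.56 log units; beyond the scatter) with the 5-fluoro-2-methylphenyl kept, while compound 1 carries that same group and gives 171000 nM with phenyl in that place, so the 5-fluoro-2-methylphenyl alone does not bring a low number. Nothing measured here explains why either change has the size it has.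

The compounds shown do not tell whether the methyl would give a step of similar size with phenyl in place of pyridin-4-yl. They also leave open whether the methyl itself matters or whether another group on the same aromatic carbon, such as ethyl, methoxy or chloro, would do as well.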